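The source may hold more compounds than are shown below. What is called first, only, known or untested is meant among the compounds shown, and "the series" means these compounds.

Measured compounds:
compound 1 `O=C1c2ccccc2C(=O)N1CNc1ccc(F)cc1` — 8740 nM
compound 2 `O=C1c2ccccc2C(=O)N1CNc1ccc(Cl)cc1` — "not determined" (no result reported)
compound 3 `CC(C)c1ccc(NCN2C(=O)c3ccccc3C2=O)cc1` — "not determined" (no result reported)

In an assay on isolated protein for inhibition of ribosomal protein S6 kinase alpha-2 (Homo sapiens), read by fluorescence, with a stated time of 20 min (on this read-out lower numbers stand for stronger inhibition and higher numbers for weaker inhibition), compound 1 gives 8740 nM. Compound 2 and compound 3 have no single number in this assay, so compound 3 stands without a value, alongside the one other entry that also lacks a number. Compound 4 `COc1ccc(NCN2C(=O)c3ccccc3C2=O)cc1` carries methoxy in place of isopropyl on an aromatic carbon. Since compound 3 has no number, the size and direction of the step to compound 4 in this assay cannot be gauged from the data; the only anchor in the series is compound 1, and nothing shown indicates that a change on that aromatic carbon moves potency beyond the scatter. Compound 4 is therefore expected to fall near 9000 nM, within 2000 nM to 40000 nM, with a real chance that no number is reported.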

Compound 4, half-maximal inhibitory concentration: 470 nM
Beside the measured number, compound 4's estimate is 19-fold (1.28 log units) above it; measured number outside the range, below it.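

In this assay methoxy in place of fluoro gives a 19-fold lower number from compound 1 to compound 4 (1.27 log units; beyond the scatter) on this aromatic carbon, para to a large group. Within the data shown here, this is the first sign that the series responds to a change at this position. Steps involving compound 2 or compound 3 cannot be read, so chloro and isopropyl remain unranked against methoxy. Nothing at hand bears on the reason for the step.

Open, as far as these compounds go, is whether an amine, a carboxylic acid or a longer chain ending in ethoxy on this carbon would match compound 4. Also open, from the compounds shown here alone, is whether the step holds with changes elsewhere on the shared core.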